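A few compounds are considered here, and "the series" means these few. Any claim that something is new, unique, unknown or untested is made for them only; others in the source may bear on it.

Compound 1 `CSc1nc2sncc2n1[C@H]1C[C@H](O)[C@@H](CO)O1` and compound 2 `OC[C@H]1O[C@@H](n2c(SCc3ccccc3)nc3sncc32)C[C@@H]1O` share one core and differ in a single place: phenyl in place of hydrogen on a saturated chain carbon bound to a sulfur. In a functional assay on KB cells (Homo sapiens) for antiproliferative activity (a higher number here means a weaker inhibitor, a lower number a stronger inhibitor), compound 1 gives 6000 nM, and compound 2 gives 3000 nM, so the change made a 2.0-fold lower number from compound 1 to compound 2 (0.30 log units; within the scatter). Compound 3 `CSc1nc2c(C)nsc2n1[C@@H]1O[C@H](CO)[C@@H](O)[C@@H]1O` carries a different core; how it differs from the core of compound 1 is not broken down here. For compound 3 this assay reports only a limit, > 100000 nM. Compound 4 `Cc1nsc2c1nc(SCc1ccccc1)n2[C@@H]1O[C@H](CO)[C@@H](O)[C@@H]1O` is compound 3 with the same change applied: phenyl in place of hydrogen on a saturated chain carbon bound to a sulfur. Because that change gave only a 2.0-fold lower number from compound 1 to compound 2 (0.30 log units; within the scatter), a similarly small step is expected from compound 3 to compound 4, and since compound 3 sits at the limit of > 100000 nM in this assay, at which 1 of the 3 values shown sits, compound 4 will probably also yield only a limit. For compound 4 the expected step is a step that the limit leaves unreadable from compound 3 to compound 4. For compound 4 the estimate is 120000 nM, with an expected range from 30000 nM to 500000 nM.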

Compound 4, half-maximal inhibitory concentration: > 100000 nM
Compound 4: only a limit was reported (the forecaster's own chance of this, stated with the estimate: 65%); the middle value does not contradict the limit.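

Compound 3 and compound 4 each give only a limit in this assay, so the step between them cannot be read: the limit of > 100000 nM in this assay, at which 2 of the 4 values shown sit.

On these data alone, how strongly either compound acts, and whether phenyl in place of hydrogen changes anything on the core of compound 3, stays open.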